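The compounds below may be only part of what the source reports. "The series", "measured", "known", "first", "only" and "open" are said of these compounds alone.

Working notes on the propargylthio series. Compound 1 `C#CCSc1nc(NCCC(C)C)c2ccncc2n1` carries an isopentyl group on the ring nitrogen; in a functional assay on PC-3 cells (Homo sapiens) for inhibition, read by MTT assay, with a stated time of 72 h (a lower number here means a stronger inhibitor, a higher number a weaker inhibitor), compound 1 gives > 80000 nM, which is a limit of the assay and not a number. Compound 2 `C#CCSc1nc(Nc2ccc(Cl)cc2)c2ccncc2n1` gives 19000 nM in this assay. Compound 3 `C#CCSc1nc(Nc2cccc(Cl)c2)c2ccncc2n1` gives 56500 nM in this assay. Among the two numbers read, compound 3 stands highest; its nearest neighbour is compound 2, with a 3.0-fold higher number from compound 2 to compound 3 (0.47 log units; beyond the scatter). The steps of an at least 4.2-fold lower number from compound 1 to compound 2 (0.62 log units; beyond the scatter) and an at least 1.4-fold lower number from compound 1 to compound 3 (0.15 log units; that floor lies within the scatter) rest on the limit for compound 1 (the limit of > 80000 nM in this assay, at which 1 of the 3 values shown sits) and are therefore floors only.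

Compound 4 `C#CCSc1nc(Nc2ccccc2O)c2ccncc2n1` is not yet measured. The change from compound 3 is 2-hydroxyphenyl in place of 3-chlorophenyl on a nitrogen on an aromatic ring. For the measured compounds named here, of the measured steps, only the one from compound 2 to compound 3 alters the aryl group, and that step moved a chlorine rather than exchanging it for a hydroxyl, so no measured step addresses this change directly. In this assay the expected step is a 1.1-fold lower number from compound 3 to compound 4 (0.05 log units; within the scatter), that is, no move beyond the scatter. The estimate for compound 4 is 50000 nM, with a range from 15000 nM to 80000 nM, and a fair chance that only a limit is reported.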

Compound 4, half-maximal inhibitory concentration: 18700 nM
Estimate against measurement, compound 4: 2.7-fold (0.43 log units) above; low and high end bracket the measured number.
By their numbers in this assay, from the lowest: compounds 4 and 2 (each within the scatter of the next); then compound 3. At a limit, above all of these: compound 1.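

Replacing 3-chlorophenyl with 2-hydroxyphenyl on the nitrogen gives, in this assay, a 3.0-fold lower number from compound 3 to compound 4 (0.48 log units; beyond the scatter), so this position accepts an aryl group without chlorine. Against the other chlorinated compound the picture differs, with a 1.0-fold lower number from compound 2 to compound 4 (0.01 log units; within the scatter), so 2-hydroxyphenyl and 4-chlorophenyl cannot be told apart here, and among the three aryl compounds only the 3-chlorophenyl compound stands apart, on the high side. The comparison with the isopentyl compound is an at least 4.2-fold lower number from compound 1 to compound 4 (0.63 log units; beyond the scatter), which is a floor only, since the value at its start is a limit of the assay and not a number: the limit of > 80000 nM in this assay, at which 1 of the 4 values shown sits.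

As far as these compounds go, it remains open whether the hydroxyl itself matters at all, which a methoxy or an amino group in its place on the aryl ring would begin to test. The propargylthio group and the shared core stay constant throughout, so the compounds shown say nothing about how either contributes to these numbers, nor whether any aryl group on the nitrogen can bring them much lower.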